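Swapping ethyl for cyclopropyl on the amide nitrogen

This account rests on a few compounds, and the source may have more. Where it says the series, first, only, none or still open, it means among the compounds named here.

Within the data shown here, compound 2 `CCNC(=O)c1cc(N)c(Nc2ccc(C#N)cc2)cc1Oc1c(C)cc(CCC#N)cc1C` is one of two compounds with a number in an ADME assay on liver for metabolic stability, with Liver microsome (Homo sapiens) as the target, read by LC-MS, using microsomes, tested at 1 uM; on this read-out lower numbers stand for a shorter-lived compound and higher numbers for a longer-lived compound: compound 2 gives 2.88 h, and compound 1 `Cc1cc(CCC#N)cc(C)c1Oc1cc(Nc2ccc(C#N)cc2)c(N)cc1C(=O)N(C)C` gives 1.65 h, so the two sit within the scatter of each other, the only known step being a 1.7-fold higher number from compound 1 to compound 2 (0.24 log units; within the scatter). Compound 3 `Cc1cc(CCC#N)cc(C)c1Oc1cc(Nc2ccc(C#N)cc2)c(N)cc1C(=O)NC1CC1` differs from compound 2 by cyclopropyl in place of ethyl on an amide-type nitrogen. Among the measured compounds shown here, the one step that bears on this, a change of the same group on the same amide nitrogen, stayed within the scatter, so no step beyond the scatter is expected, that is a 1.0-fold lower number from compound 2 to compound 3 (0.01 log units; within the scatter). Compound 3 is therefore estimated at 2.8 h, between 1.4 h and 5.6 h.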

Compound 3, half-life: 1.05 h
Beside the measured number, compound 3's estimate is 2.7-fold (0.43 log units) above it; measured number below the stated range.
By their numbers in this assay, from the lowest: compounds 3, 1 and 2 (each within the scatter of the next, the first and the last beyond it).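

In this assay, among these compounds, the group on this amide nitrogen can matter: cyclopropyl in place of ethyl gives a 2.7-fold lower number from compound 2 to compound 3 (0.44 log units; beyond the scatter) and is the first step here beyond the scatter, though a modest one. Cyclopropylamino in place of dimethylamino stays within the scatter, with a 1.6-fold lower number from compound 1 to compound 3 (0.20 log units; within the scatter) as its step. No measured data accompany these numbers to explain the step from ethyl to cyclopropyl.

From the compounds shown here alone, how an isopropyl or cyclobutyl group on this nitrogen would read stays open. So does whether the ring of cyclopropyl or its extra carbon goes with the lower number.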